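Isopropyl in place of isobutyl, compound 2 to compound 3

The compounds below may be only part of what the source reports. "The series", "measured", "known", "first", "only" and "open" are said of these compounds alone.

In an ADME assay on a cell-free system (plasma, Rattus norvegicus) for metabolic stability, read by LC-MS, with a stated time of 1 h, at 37 degrees C, tested at 100 uM (a lower number here means that less of the compound is left, a higher number that more of the compound is left), compound 1 (`Cn1sc2cc(OCc3cccc(-c4ccc(Cl)c(C(=O)O)c4)c3)ccc2c1=O`) gives 100% and compound 2 (`CC(C)CCn1sc2cc(OCc3cccc(-c4ccc(Cl)c(C(=O)O)c4)c3)ccc2c1=O`) gives 91% so the two stand within the scatter of each other. Compound 3 (`CC(C)Cn1sc2cc(OCc3cccc(-c4ccc(Cl)c(C(=O)O)c4)c3)ccc2c1=O`) carries isopropyl in place of isobutyl on a saturated chain carbon bound to an aromatic nitrogen. Among the compounds with values here, the only measured step bearing on this change is a number 9 percentage points lower from compound 1 to compound 2 (within the scatter) and it stays within the scatter, so no step beyond the scatter is expected in this assay. The expected step is small (a number 2 percentage points higher from compound 2 to compound 3 (within the scatter)). For compound 3 the estimate is 93% (expected range 80% to 100%).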

Compound 3, percent of the compound remaining: 95%
The estimate for compound 3 lay 2 percentage points below the measured number; measured number inside the range.
By their numbers in this assay, from the lowest: compounds 2, 3 and 1 (each within the scatter of the next).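

In this assay, isopropyl in place of isobutyl gives a number 4 percentage points higher from compound 2 to compound 3 (within the scatter), and isopropyl in place of hydrogen gives a number 5 percentage points lower from compound 1 to compound 3 (within the scatter). The change on a saturated chain carbon bound to an aromatic nitrogen therefore adds a third compound to this position, and compounds 1, 2 and 3 all stand within the scatter of one another. Nothing available accounts for this reading. Still open, as far as these compounds go, is whether an amine or a hydroxyl on this chain would move the number beyond the scatter. From the compounds shown here alone, a ring at this position remains equally open.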